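Trifluoromethoxy for Trifluoromethyl on a Desaturase Inhibitor Core

This account rests on a few compounds, and the source may have more. Where it says the series, first, only, none or still open, it means among the compounds named here.

In an assay for inhibition of acyl-CoA desaturase 1 (Rattus norvegicus) (a lower number here means a stronger inhibitor, a higher number a weaker inhibitor), compound 1 `Cn1ccc(NC(=O)c2cn(Cc3cccc(C(F)(F)F)c3)cn2)n1` gives 11 nM, the lower of the two numbers measured, although the step of a 1.5-fold higher number from compound 1 to compound 2 (0.16 log units; within the scatter) to compound 2 `Cn1ccc(NC(=O)c2cn(Cc3ccc(Cl)c(C(F)(F)F)c3)cn2)n1`, which gives 16 nM, lies within the scatter. Compound 3 `Cn1ccc(NC(=O)c2cn(Cc3cccc(OC(F)(F)F)c3)cn2)n1` differs from compound 1 by trifluoromethoxy in place of trifluoromethyl on an aromatic carbon. Among the compounds with values here, no measured step touches this group; the single chloro step shows only a small change elsewhere on the same ring. Compound 3 is therefore expected to stay close to compound 1, with a 1.3-fold higher number from compound 1 to compound 3 (0.10 log units; within the scatter) and an estimated 14 nM (range 5 nM to 40 nM).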

Compound 3, half-maximal inhibitory concentration: 32 nM
Compound 3: the middle estimate sits 2.3-fold (0.36 log units) below what was measured; measured number inside the range.
By their numbers in this assay, from the lowest: compounds 1, 2 and 3 (each within the scatter of the next, the first and the last beyond it).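

Within the data shown here, at this place on the ring, meta to a large group, the substituent matters: trifluoromethoxy in place of trifluoromethyl gives a 2.9-fold higher number from compound 1 to compound 3 (0.46 log units; beyond the scatter) in this assay, a modest loss and the first step beyond the scatter. A single added oxygen between the ring and the fluorinated carbon is thus enough to shift the number. Nothing available explains this step.

From the compounds shown here alone, it remains open how a methoxy group or a nitrile would read at this place. Whether the chloro step would stay as small alongside trifluoromethoxy is also unresolved.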